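The compounds below may be only part of what the source reports. "The series", "measured", "known", "first", "only" and "open" are said of these compounds alone.

Three measured compounds, all read in an assay on CHO cells for antagonist activity at transient receptor potential cation channel subfamily V member 1 (Homo sapiens), read by FLIPR; on this read-out lower numbers stand for stronger inhibition and higher numbers for weaker inhibition:

Compound 1 `CC(C(=O)NCc1ccc(C(F)(F)F)cc1N1CCCCCC1)c1ccc(NS(C)(=O)=O)c(F)c1` gives 1.6 nM
Compound 2 `CCC1CCN(c2cc(C(F)(F)F)ccc2CNC(=O)C(C)c2ccc(NS(C)(=O)=O)c(F)c2)CC1` gives 0.7 nM
Compound 3 `CC(C(=O)NCc1ccc(C(F)(F)F)cc1SC1CCCC1)c1ccc(NS(C)(=O)=O)c(F)c1` gives 0.3 nM

Compound 3 stands lowest of the three; its nearest neighbour is compound 2, reached by a 2.3-fold lower number from compound 2 to compound 3 (0.37 log units; beyond the scatter), and the furthest is compound 1, reached by a 5.3-fold lower number from compound 1 to compound 3 (0.73 log units; beyond the scatter). Compound 4 `COc1ccc(CSc2cc(C(F)(F)F)ccc2CNC(=O)C(C)c2ccc(NS(C)(=O)=O)c(F)c2)cc1` has not yet been measured. It differs from compound 3 in one place: 4-methoxybenzyl in place of cyclopentyl on a sulfur. Among the measured compounds shown here, none of the measured steps touches this place. For the measured compounds named here, the steps so far exchange the whole group on the aromatic carbon, and both of them, a 5.3-fold lower number from compound 1 to compound 3 (0.73 log units; beyond the scatter) and a 2.3-fold lower number from compound 2 to compound 3 (0.37 log units; beyond the scatter), ended at the cyclopentylsulfanyl group of compound 3. How a 4-methoxybenzyl behaves on that sulfur is therefore untested. The expected step for compound 4 in this assay is a 2.0-fold higher number from compound 3 to compound 4 (0.30 log units; within the scatter), a small move that may not pass the scatter. Compound 4 is estimated at 0.6 nM, within a range from 0.1 nM to 3 nM.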

Compound 4, inhibition constant: 2.3 nM
Compound 4: middle estimate off by 3.8-fold (0.58 log units), on the low side, within the range that was stated.
By their numbers in this assay, from the lowest: compound 3; then compound 2; then compounds 1 and 4 (each within the scatter of the next).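

On the sulfur whose other neighbour is an aromatic carbon, the group carried by that sulfur clearly matters: in this assay, 4-methoxybenzyl in place of cyclopentyl gives a 7.7-fold higher number from compound 3 to compound 4 (0.88 log units; beyond the scatter) and so takes away the edge seen with compound 3. The sulfur alone therefore does not secure a low number, since (4-methoxybenzyl)sulfanyl in place of 4-ethylpiperidin-1-yl gives a 3.3-fold higher number from compound 2 to compound 4 (0.52 log units; beyond the scatter) and in place of azepan-1-yl gives a 1.4-fold higher number from compound 1 to compound 4 (0.16 log units; within the scatter), which leaves those two compounds indistinguishable. Nothing available explains why the group on the sulfur has this effect.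

The compounds shown leave open whether the higher number follows the benzyl or its methoxy group, a question that a plain benzyl or a cyclohexyl on the same sulfur would help to settle. They also leave open how a short chain such as ethyl would read there.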